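Extending the chain of compound 1 by three carbons

The source may hold more compounds than are shown below. What is called first, only, known or untested is meant among the compounds shown, and "the series" means these compounds.

Compound 1 `CCCCCCCCCCCCCCCCc1c(C)c(N(C)C)nc(C)c1O` gives 91% in a functional assay on cells (Lymphocyte, Homo sapiens) for inhibition, read by flow cytometry, using a membrane potential dye, with a stated time of 16 h, tested at 500 nM; a higher number here means a stronger effect of the compound at the concentration tested, a lower number a weaker effect.
Compound 2 `CCCCCCCCCCCCCCCCc1nc(N2CCC2)c(C)c(C)c1O` gives 85% in this assay.
Compound 3 `CCCCCCCCCCCCCCCCc1c(C)c(N2CCC2)nc(C)c1O` gives 89% in this assay.

Compound 1 carries the highest of the three numbers shown, but its nearest neighbour, compound 3, sits only a number 2 percentage points lower from compound 1 to compound 3 (within the scatter), and compound 2 also lies within the scatter of compound 1, so no order can be read among them. The single one-place step shown, a number 2 percentage points lower from compound 1 to compound 3 (within the scatter), concerns the group on the aromatic carbon and does not touch the chain.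

Compound 4 `CCCCCCCCCCCCCCCCCCCc1c(C)c(N(C)C)nc(C)c1O` differs from compound 1 by propyl in place of hydrogen on a saturated chain carbon, ten or more bonds along the chain from an aromatic carbon. Among the compounds with values here, no measured pair here changes that chain, so there is no step on which to lean; all three measured chains are alike, and all three numbers are within the scatter of one another. The account therefore expects compound 4 to move by about a number 4 percentage points lower from compound 1 to compound 4 (within the scatter) in this assay, that is, no step beyond the scatter. Compound 4 is estimated at 87% in this assay, with a range from 72% to 97%.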

Compound 4, a percentage reported as activity, at one concentration (the size of the read-out at that concentration, not a potency): 64%
Compound 4: middle estimate off by 23 percentage points, on the high side; measured number below the stated range.
By their numbers in this assay, from the lowest: compound 4; then compounds 2, 3 and 1 (each within the scatter of the next).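

Within the data shown here, compound 4 gives the first measured change at the chain, and it shows that this far end of the molecule is not indifferent: in this assay, propyl in place of hydrogen on a saturated chain carbon, ten or more bonds along the chain from an aromatic carbon, gives a number 27 percentage points lower from compound 1 to compound 4 (beyond the scatter). Among these compounds, the one earlier step, a number 2 percentage points lower from compound 1 to compound 3 (within the scatter), concerned the group on the aromatic carbon and stayed within the scatter, whereas this one does not. Nothing among the data shown explains the step.

A single extension leaves open whether the number falls gradually or abruptly with chain length, which ethyl or butyl in the same place would help to settle. Also open, going by these compounds, are how a carboxylic acid or an amine at the chain end would read, and whether compound 3 responds to propyl in the same way.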